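The source may report more compounds than this note shows. Statements on the series, on what has been measured and on what is new or still open speak of the compounds shown alone.

Compound 1 `Cc1ccc2c(O)cc(-c3cccc(Cl)c3)nc2n1` and compound 2 `Cc1cc(C)c2c(O)cc(-c3cccc(Cl)c3)nc2n1` share one core and differ in a single place: methyl in place of hydrogen on an aromatic carbon. In a functional assay on MDA-N cells (Homo sapiens) for antiproliferative activity (a lower number here means a stronger inhibitor of growth, a higher number a weaker inhibitor of growth), compound 1 reaches only the limit of the method, > 100000 nM. In this assay compound 2 gives 19.1 nM, so the change made an at least 5200-fold lower number from compound 1 to compound 2 (3.71 log units; beyond the scatter). The size of that step is known only as a limit because compound 1 sits at the limit of > 100000 nM in this assay, at which 1 of the 3 values shown sits.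

Compound 3 `Cc1ccc2c(O)cc(-c3ccc4ccccc4c3)nc2n1` carries a different core, and how its core differs from that of compound 1 is not broken down here. In this assay compound 3 gives 1950 nM. Compound 4 `Cc1cc(C)c2c(O)cc(-c3ccc4ccccc4c3)nc2n1` is made from compound 3 by the same change: methyl in place of hydrogen on an aromatic carbon.

Expected step from compound 3 to compound 4: a 650-fold lower number from compound 3 to compound 4 (2.81 log units; beyond the scatter), a large drop, resting on an at least 5200-fold lower number from compound 1 to compound 2 (3.71 log units; beyond the scatter) seen on the other core. Compound 4 is therefore estimated at 3 nM, between 0.3 nM and 50 nM.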

Compound 4, concentration for 50% growth inhibition: 3240 nM
Beside the measured number, compound 4's estimate is 1100-fold (3.03 log units) below it, and the stated range ends below it.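

In this assay, methyl in place of hydrogen on an aromatic carbon gives a 1.7-fold higher number from compound 3 to compound 4 (0.22 log units; within the scatter), so the large drop seen on the other core does not carry over to this one: the same change on two cores in this assay, an at least 5200-fold lower number (3.71 log units; beyond the scatter) from compound 1 to compound 2 and a 1.7-fold higher number (0.22 log units; within the scatter) from compound 3 to compound 4, at least 8600-fold (3.93 log units) apart, beyond the scatter of two such steps. This comparison rests on just one pair of compounds for each core, and it does not show which feature of the two cores sets the results apart. Compound 1 stands at a limit of the assay, not at a number: the limit of > 100000 nM in this assay, at which 1 of the 4 values shown sits.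

Still open, going by these compounds, is whether a longer chain such as ethyl, or an amine, on the same aromatic carbon would behave differently on each core. Also open, on these data alone, is whether further cores would follow the pair ending in compound 2 or the pair ending in compound 4.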